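A few compounds are considered here, and "the series" means these few. Any claim that something is new, unique, unknown or untested is made for them only; others in the source may bear on it.

Of the compounds shown here, three that share one core have been measured in a functional assay for inhibition, with Homo sapiens as the target (a lower number here means a stronger inhibitor, a higher number a weaker inhibitor), and they differ only in the group on the saturated chain carbon bound to an oxygen on an aromatic ring. Compound 1 `CC(C)(C)Sc1c(CC(C)(C)C(=O)O)n(Cc2ccc(Cl)cc2)c2ccc(OCc3ccc4cc(F)ccc4n3)cc12` gives 2 nM, compound 2 `CC(C)(C)Sc1c(CC(C)(C)C(=O)O)n(Cc2ccc(Cl)cc2)c2ccc(OCc3ccc4cccnc4n3)cc12` gives 6 nM, and compound 3 `CC(C)(C)Sc1c(CC(C)(C)C(=O)O)n(Cc2ccc(Cl)cc2)c2ccc(OCc3ccc4cnccc4n3)cc12` gives 3 nM. Compound 3 cannot be told apart from either of the others, as both a 1.5-fold higher number from compound 1 to compound 3 (0.18 log units; within the scatter) and a 2.0-fold lower number from compound 2 to compound 3 (0.30 log units; within the scatter) stay within the scatter.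

Compound 4 `CC(C)(C)Sc1c(CC(C)(C)C(=O)O)n(Cc2ccc(Cl)cc2)c2ccc(OCc3nc4ccccc4s3)cc12` brings a new change at that same place: a group of 9 heavy atoms (7 carbon, 1 nitrogen, 1 sulfur; one five-membered aromatic ring with 2 hetero atoms, one six-membered aromatic ring of carbon only) in place of a group of 10 heavy atoms (8 carbon, 2 nitrogen; 2 six-membered aromatic rings with 1 hetero atom each), on a saturated chain carbon bound to an oxygen on an aromatic ring. Among the compounds with values here, the entering group is 1,3-benzothiazol-2-yl, with a five-membered aromatic ring that none of the measured compounds carries, so the earlier steps are only an indirect guide. They are still the best evidence available. The largest of them, a 3.0-fold higher number from compound 1 to compound 2 (0.48 log units; beyond the scatter), is modest, and the other two are smaller. Going by these compounds, on that basis, no step beyond the scatter is expected in this assay, and the direction stays open. The expected step is a 1.3-fold higher number from compound 3 to compound 4 (0.12 log units; within the scatter). For compound 4 the estimated value is 4 nM, with an expected range from 1.5 nM to 12 nM.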

Compound 4, half-maximal inhibitory concentration: 3 nM
The estimate for compound 4 lay 1.3-fold (0.12 log units) above the measured number, and the stated range covers the measured number.
By their numbers in this assay, from the lowest: compounds 1, 3, 4 and 2 (each within the scatter of the next, the first and the last beyond it).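

In this assay, putting 1,3-benzothiazol-2-yl on the saturated chain carbon bound to an oxygen on an aromatic ring gives no change at the digits printed from compound 3 to compound 4 (within the scatter) and thus shows that a five-membered aromatic ring with sulfur in it can stand at this place without a measurable loss, which the earlier groups, all built from six-membered rings, could not show. The comparisons with the other two groups agree, with a 2.0-fold lower number from compound 2 to compound 4 (0.30 log units; within the scatter) and a 1.5-fold higher number from compound 1 to compound 4 (0.18 log units; within the scatter) both printed as within the scatter, so this group cannot be told apart from any of the three earlier ones, even though the groups of compound 1 and compound 2 do differ beyond the scatter. No supporting data are available to say what lies behind this result.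

All four groups shown are aromatic and contain two rings, so it remains open whether a single phenyl ring, a saturated piperidine ring or a plain butyl chain would keep the numbers this low. The compounds also leave open how far this freedom extends, for instance whether a larger three-ring group such as acridinyl would still fit the pattern.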